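Trimethoxyphenyl Analogue of a Pyrazoline Sulfonamide Series

The source may hold more compounds than are shown below. What is called first, only, known or untested is meant among the compounds shown, and "the series" means these compounds.

Compound 1 `Cc1cc(O)c(C2=NN(c3ccc(S(N)(=O)=O)cc3)C(c3ccccc3O)C2)cc1Cl`: 1950 nM
Compound 2 `Cc1cc(O)c(C2=NN(c3ccc(S(N)(=O)=O)cc3)C(c3ccccc3Cl)C2)cc1Cl`: 1810 nM
Compound 3 `COc1ccc(C2CC(c3cc(Cl)c(C)cc3O)=NN2c2ccc(S(N)(=O)=O)cc2)cc1OC`: 1930 nM

In a functional assay on COLO 205 cells (Homo sapiens) for antiproliferative activity, with a stated time of 48 h (a lower number here means a stronger inhibitor of growth, a higher number a weaker inhibitor of growth), compound 3 gives 1930 nM, the second highest of the three numbers, yet within the scatter of both neighbours. Compound 4 `COc1ccc(C2CC(c3cc(Cl)c(C)cc3O)=NN2c2ccc(S(N)(=O)=O)cc2)c(OC)c1OC` differs from it by methoxy in place of hydrogen on an aromatic carbon. The measured steps on the same ring, a 1.0-fold lower number from compound 1 to compound 3 (0.00 log units; within the scatter) and a 1.1-fold higher number from compound 2 to compound 3 (0.03 log units; within the scatter), show that swapping the aryl on the saturated ring carbon left this assay unchanged. The added methoxy is therefore expected to bring no step beyond the scatter, so a 1.0-fold higher number from compound 3 to compound 4 (0.02 log units; within the scatter) is the expected outcome. Compound 4 is estimated at 2000 nM, within a range from 1000 nM to 4000 nM.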

Compound 4, concentration for 50% growth inhibition: 1720 nM
Compound 4: middle estimate off by 1.2-fold (0.07 log units), on the high side, and the stated range covers the measured number.
By their numbers in this assay, from the lowest: compounds 4, 2, 3 and 1 (each within the scatter of the next).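

In this assay, the change from 3,4-dimethoxyphenyl to 2,3,4-trimethoxyphenyl adds a group to the aryl rather than swapping the aryl, and it gives a 1.1-fold lower number from compound 3 to compound 4 (0.05 log units; within the scatter). A methoxy ortho to a large group and ortho to a methoxy group thus leaves this number unmoved, and the trimethoxyphenyl stands level with the aryls of the other compounds, with a 1.1-fold lower number from compound 2 to compound 4 (0.02 log units; within the scatter) and a 1.1-fold lower number from compound 1 to compound 4 (0.05 log units; within the scatter). Nothing available explains why these aryl changes leave the number flat. As far as these compounds go, it remains open whether an amine, a carboxylic acid or a longer alkoxy chain on this aryl would bring a step beyond the scatter.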